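A larger side group on a compound at the limit

A few compounds are considered here, and "the series" means these few. Any claim that something is new, unique, unknown or untested is made for them only; others in the source may bear on it.

Compound 1 `Cc1cn([C@@H]2S[C@H](CO)[C@@H](O)[C@@H]2O)c(=O)[nH]c1=O` gives > 100 ug/mL in a functional assay on CCRF-HSB-2 cells (Homo sapiens) for antiproliferative activity (a lower number here means a stronger inhibitor, a higher number a weaker inhibitor), as a limit of the assay, not a number. Compound 2 `CCc1cn([C@H]2S[C@H](CO)[C@@H](O)[C@@H]2O)c(=O)[nH]c1=O` gives > 100 ug/mL as a limit too. Compound 3 `Cc1cn([C@H]2S[C@H](CO)[C@@H](O)[C@@H]2O)c(=O)[nH]c1=O` gives 42 ug/mL as a true number. Compound 4 `O=c1[nH]c(=O)n([C@@H]2S[C@H](CO)[C@@H](O)[C@@H]2O)cc1/C=C/Cl` keeps the drawn configuration of compound 1 but has 2-chloroethenyl in place of methyl on an aromatic carbon on the shared core. Of the measured steps, an at least 2.3-fold lower number from compound 1 to compound 3 (0.37 log units; beyond the scatter) rests on the fact that compounds 1 and 3 differ only in the configuration as drawn and says little about this swap. The other shows an at least 2.3-fold lower number from compound 2 to compound 3 (0.37 log units; beyond the scatter) on losing a methyl, whereas compound 4 carries a larger group. No gain is therefore expected, and the estimated change is a number no higher from compound 1 to compound 4 (the limit leaves the size open) with nothing beyond the scatter. Compound 4 is expected at about 100 ug/mL with an estimated range of 40 ug/mL to 250 ug/mL and may well read as a limit.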

Compound 4, half-maximal inhibitory concentration: > 100 ug/mL
Compound 4 ended at the assay's limit (the forecaster's own chance of this, stated with the estimate: 75%); the middle value lies on the limit itself.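

Compound 1 and compound 4 both read as limits of the assay rather than true numbers, so the step between them cannot be read. The compounds shown leave open whether 2-chloroethenyl in place of methyl changes the activity at all.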